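This account rests on a few compounds, and the source may have more. Where it says the series, first, only, none or still open, it means among the compounds named here.

Compound 1 `O=C(O)c1cc(N2C(=O)C3=C(CCCC3)C2=O)ccc1Cl`: > 100000 nM
Compound 2 `CCCOC(=O)c1cc(N2C(=O)C3=C(CCCC3)C2=O)ccc1Cl`: 1860 nM

In a functional assay on the whole organism with Scenedesmus acutus as the target (a higher number here means a weaker inhibitor, a lower number a stronger inhibitor), compound 1 reaches only the limit of the assay, > 100000 nM, so no number is known for it. Within the data shown here, compound 2 gives 1860 nM in this assay, the only number among the two values shown. Among the measured compounds shown here, the single measured step, an at least 53-fold lower number from compound 1 to compound 2 (1.73 log units; beyond the scatter), turns the free acid into the propyl ester and says nothing about the shape of the chain once it is present. Compound 3 `CC(C)COC(=O)c1cc(N2C(=O)C3=C(CCCC3)C2=O)ccc1Cl` differs from compound 2 by methyl in place of hydrogen on a saturated chain carbon bound to two saturated chain carbons; a small addition on the ester chain, with no donor, acceptor or charge entering. The measured step concerns a different place and offers no direct guide. Compound 3 is therefore expected to stay near compound 2 in this assay. The step of a 1.2-fold lower number from compound 2 to compound 3 (0.09 log units; within the scatter) is expected to fall within the scatter. Compound 3 is estimated at 1500 nM, within 500 nM to 5000 nM.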

Compound 3, half-maximal inhibitory concentration: 759 nM
Compound 3: the middle estimate sits 2.0-fold (0.30 log units) above what was measured; measured number inside the range.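

In this assay, the ester chain proves sensitive to its shape and not merely to its presence: methyl in place of hydrogen on a saturated chain carbon bound to two saturated chain carbons, which turns propyl into isobutyl, gives a 2.5-fold lower number from compound 2 to compound 3 (0.39 log units; beyond the scatter). The earlier step set only the propyl ester against the free acid, and the isobutyl ester now shows the same direction with an at least 130-fold lower number from compound 1 to compound 3 (2.11 log units; beyond the scatter). That larger step rests on a limit for compound 1 and not on a number: the limit of > 100000 nM in this assay, at which 1 of the 3 values shown sits.

How far this shape dependence extends remains open, as the compounds shown include no longer chain such as pentyl and no tert-butyl or cyclohexyl ester. Whether an amide in place of the ester would keep a comparable number is also unresolved.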